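Working notes on compounds 1 to 4

The compounds below may be only part of what the source reports. "The series", "measured", "known", "first", "only" and "open" are said of these compounds alone.

Measured in an ADME assay on J774 cells (Mus musculus) for cytotoxicity, read by MTT assay, with a stated time of 48 h, tested at 150 ug/mL (a lower number here means a stronger effect, a higher number a weaker effect of the compound at the concentration tested), so far:
Compound 1, `O=C(N/N=C/c1ccccc1Br)c1cnccn1`, gives 91%.
Compound 2, `O=C(N/N=C/c1ccc(Br)cc1)c1cnccn1`, gives 94%.
Compound 3, `COc1ccccc1/C=N/NC(=O)c1cnccn1`, gives 97%.

Compounds 1 and 2 are built from the same atoms joined differently; the difference between their two cores is not broken down here. In this assay the two values lie within the usual scatter of each other, and compound 3 also sits within the scatter of both, so no order among the three measured compounds is claimed.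

One structural change is seen twice in the set. From compound 1 to compound 3 it is methoxy in place of bromo on an aromatic carbon and gives a number 6 percentage points higher from compound 1 to compound 3 (within the scatter). Compound 4, `COc1ccc(/C=N/NC(=O)c2cnccn2)cc1`, is not yet measured; it differs from compound 2 by methoxy in place of bromo on an aromatic carbon. For the measured compounds named here, the change is the same kind of change as the one from compound 1 to compound 3, but the place is not the same: in the first case the group stands ortho to a large group, in the second para to a large group.

The expectation for compound 4 rests on that single earlier step, a step within the scatter, and on compound 2 giving 94%. Compound 4 is therefore expected to show a number 2 percentage points higher from compound 2 to compound 4 (within the scatter) in this assay, of the same small size as the earlier step. Compound 4 is estimated at 96%, with a range from 88% to 102%.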

Compound 4, a percentage reported as activity, at one concentration (the size of the read-out at that concentration, not a potency): 55%
Estimate against measurement, compound 4: 41 percentage points above, and the stated range ends above it.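

With the methoxy para to a large group, the change gives a number 39 percentage points lower from compound 2 to compound 4 (beyond the scatter) in this assay, so on this core replacing bromo with methoxy is accompanied by a large fall in the number. The step therefore does not carry over as a single value from one core to the other in this series: the same change on two cores in this assay, a number 6 percentage points higher (within the scatter) from compound 1 to compound 3 and a number 39 percentage points lower (beyond the scatter) from compound 2 to compound 4, 45 percentage points apart, beyond the scatter of two such steps. For the compounds shown here, this does not show why the two steps differ, since the two pairs differ in where the group stands and there is only one pair for each case, so the data cannot say whether the result belongs to the place, to the methoxy group or to something specific to compound 4, and they give no rule for any further core.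

The compounds shown leave open whether the low number of compound 4 is tied to methoxy itself or would also appear with another group at that place, such as an amine, a carboxylic acid or a longer alkoxy chain. Also open, on these data alone, is whether any of these groups would read alike on the core of compound 1 and on the core of compound 2 in this assay.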